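The compounds below may be only part of what the source reports. "The series", "measured", "known", "first", "only" and "open" are said of these compounds alone.

Compound 1 `COc1cc(C(=O)/C=C/c2cn(-c3ccccc3)nc2-c2ccsc2)cc(OC)c1OC` gives 3600 nM in a functional assay on Huh-7 cells (Homo sapiens) for inhibition, read by sulforhodamine B assay, with a stated time of 72 h; on this read-out lower numbers stand for stronger inhibition and higher numbers for weaker inhibition.
Compound 2 `COc1ccc(C(=O)/C=C/c2cn(-c3ccccc3)nc2-c2ccsc2)cc1OC` gives 2900 nM in this assay.

Only compound 1 stands beside compound 2, and the step of a 1.2-fold lower number from compound 1 to compound 2 (0.09 log units; within the scatter) lies within the scatter, so the two compounds are not separated by this read-out. Compound 3 `COc1ccc(C(=O)/C=C/c2cn(-c3ccccc3)nc2-c2cccnc2)cc1OC` differs from compound 2 by pyridin-3-yl in place of thiophen-3-yl on an aromatic carbon. Within the data shown here, no measured step touches this part of the molecule: the only step known, from compound 1 to compound 2, concerns a methoxy on another ring and did not reach beyond the scatter. There is therefore nothing in the numbers that points to a step in this assay beyond the scatter in either direction, and the range must stay wide. Compound 3 is expected to give about 3500 nM, between 1200 nM and 10000 nM. The expected step is a 1.2-fold higher number from compound 2 to compound 3 (0.08 log units; within the scatter).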

Compound 3, half-maximal inhibitory concentration: 3100 nM
Compound 3: the middle estimate sits 1.1-fold (0.05 log units) above what was measured; the measured number falls inside the stated range.
By their numbers in this assay, from the lowest: compounds 2, 3 and 1 (each within the scatter of the next).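

Among these compounds, this is the first look at the place on the five-membered aromatic ring with 2 nitrogen, since the earlier step concerned only a methoxy on another ring. In this assay, replacing thiophen-3-yl with pyridin-3-yl gives a 1.1-fold higher number from compound 2 to compound 3 (0.03 log units; within the scatter), so a five-membered aromatic ring holding sulfur and a six-membered aromatic ring holding nitrogen are not separated here. No measurement available here explains this result.

With all three compounds within the scatter of their neighbours, no change shown so far moves the number beyond it. Going by these compounds, it remains open whether a group without an aromatic ring at this place, such as a morpholine, a carboxylic acid or a longer alkyl chain, would give a step beyond the scatter in either direction.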